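The compounds below may be only part of what the source reports. "The series", "measured", "known", "first", "only" and "open" are said of these compounds alone.

Of the compounds shown here, two from one series have been tested in a functional assay on the whole organism for inhibition, with Mus musculus as the target, at a dose of 30 mg/kg by the oral route; a higher number here means more inhibition at the dose given (going by the name of the read-out), a lower number less inhibition. Compound 1, `O=C(NCCCOc1ccc2nc(O)ccc2c1)N(C1CC1)[C@@H]1CCC[C@H]1O`, gives 67% in this assay, the higher of the two numbers recorded. Compound 2, `CCN(CCCOc1ccc2nc(O)ccc2c1)C(=O)N(C)C1CCCCC1`, gives 58% in this assay, a number that lies within the usual scatter of the result for compound 1, so on these measurements the two cannot be told apart. Going by the values given here, no pair among the measured compounds differs in a single place, so no step between them has been sized.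

Compound 3, `CCCCO[C@H]1CCCC[C@@H]1N(C(=O)NCCCOc1ccc2nc(O)ccc2c1)C1CC1`, has not yet been measured in this assay. It differs from compound 1 in one place: 2-butoxycyclohexyl in place of 2-hydroxycyclopentyl on an amide-type nitrogen. The leaving group carries a hydrogen-bond donor, the entering group none, and the entering group has more heavy atoms. Among the compounds with values here, with no measured step to lean on, the size of this change can only be guessed. Compound 3 is expected to give about 52%, within a range from 25% to 75%, because compound 1 gives 67% and a larger group with no donor is more often a loss than a gain. The step expected here, a number 15 percentage points lower from compound 1 to compound 3 (beyond the scatter), is a modest drop that may still fall within the scatter.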

Compound 3, a percentage reported as inhibition, in the whole organism at one dose (the size of the read-out at that dose, not a potency): 33%
The estimate for compound 3 lay 19 percentage points above the measured number; low and high end bracket the measured number.
By their numbers in this assay, from the lowest: compound 3; then compounds 2 and 1 (each within the scatter of the next).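

Placing 2-butoxycyclohexyl instead of 2-hydroxycyclopentyl on the amide-type nitrogen gives, in this assay, a number 34 percentage points lower from compound 1 to compound 3 (beyond the scatter), a large step. Going by these compounds alone, this shows that the group at this position can move the read-out by more than repeated measurements would, which no earlier pair could show, as none differed in a single place. The swap alters several things at once, namely the ring size, the heavy-atom count and the loss of the hydrogen-bond donor, and nothing measured here explains the drop or singles out one of these changes.

Still open is which of these changes accounts for the loss: a 2-hydroxycyclohexyl group would keep the hydroxyl on the larger ring, while a 2-methoxycyclopentyl group would test a short ether on the smaller ring. Also open, on these data alone, is how compound 3 would behave at other doses, as a single-dose read-out gives the size of the effect at that dose and not a potency.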